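From isobutyl to cyclohexyl on a shared core

The source may report more compounds than this note shows. Statements on the series, on what has been measured and on what is new or still open speak of the compounds shown alone.

Three measured compounds share one core and differ only in the group on an aromatic carbon of the five-membered aromatic ring with two nitrogens. Compound 1 `O=C(O)c1cccc(Cc2c(-c3ccc(Cl)cc3)nn3cc(Cl)ccc23)n1` carries 4-chlorophenyl there, and in a functional assay on cells for antagonist activity at prostaglandin E2 receptor EP1 subtype (Rattus norvegicus), read by fluorescence and calcium flux, with a stated time of 60 s (on this read-out higher numbers stand for weaker inhibition and lower numbers for stronger inhibition), compound 1 gives 1100 nM. Compound 2 `O=C(O)c1cccc(Cc2c(-c3ccoc3)nn3cc(Cl)ccc23)n1` carries furan-3-yl and gives 130 nM. Compound 3 `CC(C)Cc1nn2cc(Cl)ccc2c1Cc1cccc(C(=O)O)n1` carries isobutyl and gives 200 nM, the second highest of the three numbers. The nearest neighbour is shown by a 1.5-fold higher number from compound 2 to compound 3 (0.19 log units; within the scatter), the furthest by a 5.5-fold lower number from compound 1 to compound 3 (0.74 log units; beyond the scatter); the remaining step is an 8.5-fold lower number from compound 1 to compound 2 (0.93 log units; beyond the scatter).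

Compound 4 `O=C(O)c1cccc(Cc2c(C3CCCCC3)nn3cc(Cl)ccc23)n1` is not yet measured. It differs from compound 3 by cyclohexyl in place of isobutyl on an aromatic carbon. Within the data shown here, no measured step exchanges one non-aromatic group for another; the steps of some bearing are a 5.5-fold lower number from compound 1 to compound 3 (0.74 log units; beyond the scatter) and a 1.5-fold higher number from compound 2 to compound 3 (0.19 log units; within the scatter), which show a clear drop on leaving 4-chlorophenyl but no separation between the two smaller groups. The expected step is a 1.3-fold higher number from compound 3 to compound 4 (0.10 log units; within the scatter), within the scatter. The estimate for compound 4 is 250 nM, with a range from 80 nM to 800 nM.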

Compound 4, half-maximal inhibitory concentration: 1200 nM
Beside the measured number, compound 4's estimate is 4.8-fold (0.68 log units) below it; measured number above the stated range.
By their numbers in this assay, from the lowest: compounds 2 and 3 (each within the scatter of the next); then compounds 1 and 4 (each within the scatter of the next).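

In this assay, among these compounds, the position proves to discriminate among non-aromatic groups, which no earlier step could test: there is a 6.0-fold higher number from compound 3 to compound 4 (0.78 log units; beyond the scatter), and the comparison with the five-membered aromatic ring gives a 9.2-fold higher number from compound 2 to compound 4 (0.97 log units; beyond the scatter). Aromatic character alone therefore does not sort these groups, since there is a 1.1-fold higher number from compound 1 to compound 4 (0.04 log units; within the scatter), which places cyclohexyl with 4-chlorophenyl, while furan-3-yl stays with isobutyl. Nothing available explains this separation.

The compounds shown leave open whether the higher number of compound 4 goes with the closed ring itself or with the added carbons, a question that an open hexyl chain or a cyclopentyl ring would address. On these data alone, it also remains open whether a piperidinyl group, which brings an amine into the ring, would behave like cyclohexyl at this position.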